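The source may hold more compounds than are shown below. What is called first, only, known or untested is meant among the compounds shown, and "the series" means these compounds.

Working notes on the oxalamide series.

Of the compounds shown here, three have been measured in a functional assay on FaDu cells (Homo sapiens) for cytotoxicity, read by MTT assay, with a stated time of 72 h; a higher number here means that more compound is tolerated, a lower number that less compound is tolerated. Compound 1 `COc1ccc(NC(=O)C(=O)c2cn(C(C)C)c3ncccc23)cn1` gives 126 nM. Compound 2 `CCCCn1cc(C(=O)C(=O)Nc2ccc(OC)nc2)c2ccccc21` gives 18 nM. Compound 3 `COCCn1cc(C(=O)C(=O)Nc2ccc(OC(C)(C)C)nc2)c2ccccc21` gives 858 nM. Compound 2 stands at the lowest number of the three; its gap to compound 1 and its gap to compound 3 are both beyond the usual scatter, so compound 2 is the least tolerated of the three in this assay. None of the three differs from another in one place only, so no single-point step can be read from the measured set.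

Compound 4 `COCC(C)(C)n1cc(C(=O)C(=O)Nc2ccc(OC)nc2)c2ccccc21` has not yet been measured. It differs from compound 2 as follows: 1-(methoxymethyl)-1-methylethyl in place of butyl on an aromatic nitrogen. Going by the values given here, the measured set gives no direct precedent for this change, since compound 1 and compound 3 each differ from compound 2 in more than one place. The replacement of butyl by a branched, oxygen-bearing group on the aromatic nitrogen is expected to move the number upward by a moderate step, toward more tolerated, with the step from compound 2 estimated as a 5.6-fold higher number from compound 2 to compound 4 (0.74 log units; beyond the scatter). For compound 4 the expected value in this assay is 100 nM, within a range of 25 nM to 400 nM.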

Compound 4, concentration lethal to 50% of the cells: 137 nM
For compound 4 the middle estimate is 1.4-fold (0.14 log units) below the measured one; low and high end bracket the measured number.
By their numbers in this assay, from the lowest: compound 2; then compounds 1 and 4 (each within the scatter of the next); then compound 3.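

In this assay the series now has its first single-place step: 1-(methoxymethyl)-1-methylethyl in place of butyl on the aromatic nitrogen gives a 7.6-fold higher number from compound 2 to compound 4 (0.88 log units; beyond the scatter), so the number responds to the group at this position. The entering group differs from butyl in heavy-atom count, branching and its one hydrogen-bond acceptor, and this single step cannot separate these differences. Nothing in the available data bears on the reason for the step.

The compounds shown leave open whether the branching or the ether oxygen accounts for the step, which a tert-butyl group on the same nitrogen would help to separate. Also open, going by these compounds, is how a longer chain such as hexyl, or a chain ending in an amine, would read at this position.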